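The source may report more compounds than this note shows. Statements on the series, on what has been measured and on what is new or still open speak of the compounds shown alone.

Compound 3 `CCCCCC(=O)Nc1c(OCCCn2cnc(-c3ccccc3)c2)cccc1N(C)C` gives 200 nM in an assay for inhibition of acyl-CoA:cholesterol acyltransferase (Oryctolagus cuniculus), using microsomes; on this read-out lower numbers stand for stronger inhibition and higher numbers for weaker inhibition. Compound 1 `CCCCNC(=O)Nc1c(OCCCn2cnc(-c3ccccc3)c2)cccc1N(C)C` gives 140 nM, and compound 2 `CN(C)c1cccc(OCCCn2cnc(-c3ccccc3)c2)c1NC(=O)NC1CCCC1` gives 240 nM; the three numbers lie close together, as the steps of a 1.4-fold higher number from compound 1 to compound 3 (0.15 log units; within the scatter) and a 1.2-fold lower number from compound 2 to compound 3 (0.08 log units; within the scatter) show, and the step of a 1.7-fold higher number from compound 1 to compound 2 (0.23 log units; within the scatter) also stays within the scatter. Compound 3 therefore sits among values that the data cannot tell apart.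

Compound 4 `CCCCCCNc1c(OCCCn2cnc(-c3ccccc3)c2)cccc1N(C)C` differs from compound 3 in one place: hexyl in place of pentylcarbonyl on a nitrogen on an aromatic ring. The measured steps that touch this position all exchange one carbonyl-bearing group for another, and none of them moves the number beyond the scatter. For the measured compounds named here, no measured step removes the carbonyl itself, so the data give no direct guide for this change. On that basis a step of about a 2.0-fold higher number from compound 3 to compound 4 (0.30 log units; within the scatter) is expected, with wide uncertainty. Compound 4 is estimated at 400 nM in this assay, with a range from 120 nM to 1500 nM.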

Compound 4, half-maximal inhibitory concentration: 11000 nM
Estimate against measurement, compound 4: 28-fold (1.44 log units) below; the whole stated range lies below it.
By their numbers in this assay, from the lowest: compounds 1, 3 and 2 (each within the scatter of the next); then compound 4.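

Earlier exchanges on this nitrogen on an aromatic ring replaced one carbonyl-bearing group with another and stayed within the scatter, but replacing pentylcarbonyl with hexyl removes the carbonyl and gives a 55-fold higher number from compound 3 to compound 4 (1.74 log units; beyond the scatter) (large, and beyond the scatter). The butylcarbamoyl and cyclopentylcarbamoyl compounds stand just as far from hexyl, with a 79-fold higher number from compound 1 to compound 4 (1.90 log units; beyond the scatter) and a 46-fold higher number from compound 2 to compound 4 (1.66 log units; beyond the scatter), so at this position all three carbonyl-bearing groups are separated from hexyl by a large step, while the differences among them remain within the scatter. Nothing in the data given accounts for the size of these steps.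

From the compounds shown here alone, it remains open whether a sulfonamide or a carbamate on this nitrogen would give a number near that of compound 3. Going by these compounds, it is equally open whether a shorter or longer alkyl chain there would give a number near that of compound 4.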